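From Chloro to Trifluoromethyl on a Shared Core

This account rests on a few compounds, and the source may have more. Where it says the series, first, only, none or still open, it means among the compounds named here.

In a functional assay on A549 cells (Homo sapiens) for antiproliferative activity, read by MTT assay (a higher number here means a weaker inhibitor, a lower number a stronger inhibitor), compound 2 `Cc1nn2c(-c3nc4cc(Cl)ccc4[nH]3)c(-c3ccccc3)nc2s1` gives 16900 nM and compound 1 `Cc1nn2c(-c3nc4cc(Cl)c(Cl)cc4[nH]3)c(-c3ccccc3)nc2s1` gives 13600 nM, two values that lie within the scatter of each other. Compound 3 `Cc1nn2c(-c3nc4cc(Cl)c(F)cc4[nH]3)c(-c3ccc(F)cc3)nc2s1` is reported only as a limit of the assay, > 30000 nM. For the measured compounds named here, compound 2 therefore stands level with the one other compound that has a numeric value.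

Compound 4 `Cc1nn2c(-c3nc4cc(C(F)(F)F)ccc4[nH]3)c(-c3ccccc3)nc2s1` is reached from compound 2 by placing trifluoromethyl in place of chloro on an aromatic carbon.

Going by the values given here, only one measured step bears on this change, a 1.2-fold higher number from compound 1 to compound 2 (0.09 log units; within the scatter). That step puts hydrogen in place of chloro on an aromatic carbon, and its size is small. Among the compounds with values here, no measured step covers trifluoromethyl, so the evidence is indirect, and no shift beyond the scatter is expected in this assay. The expected change is a 1.1-fold lower number from compound 2 to compound 4 (0.05 log units; within the scatter). For compound 4 the estimated value is 15000 nM, with an expected range of 7000 nM to 30000 nM.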

Compound 4, half-maximal inhibitory concentration: 13600 nM
Compound 4: middle estimate off by 1.1-fold (0.04 log units), on the high side; the measured number falls inside the stated range.
By their numbers in this assay, from the lowest: compounds 1, 4 and 2 (each within the scatter of the next). At a limit, above all of these: compound 3.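

In this assay, for the compounds shown here, the step of a 1.2-fold lower number from compound 2 to compound 4 (0.09 log units; within the scatter) replaces the only chloro of compound 2, whereas the earlier step left a chloro in place on the shared core. The printed difference is not small in size: trifluoromethyl brings 4 heavy atoms where chloro had 1, on an aromatic carbon of the six-membered ring, and the number still stays within the scatter. At this position, then, chloro is not needed to hold the value, and this exchange leaves the reading where it was.

Going by these compounds, whether a group of another kind here, such as an amine or a carboxylic acid, would move the number beyond the scatter stays open. Compound 3 differs in more than one place and is reported only as a limit of the assay, so it cannot settle this: the limit of > 30000 nM in this assay, at which 1 of the 4 values shown sits.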